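Tolerance of compound 4 after a 3-cyanophenyl swap

This account rests on a few compounds, and the source may have more. Where it says the series, first, only, none or still open, it means among the compounds named here.

In a toxicity assay on MT4 cells (Homo sapiens) for cytotoxicity, read by MTT assay (a higher number here means that more compound is tolerated, a lower number that less compound is tolerated), three compounds have been measured:
compound 1 `COc1cc(-c2ccc(C#N)cc2)ccc1Oc1cc(N)nc(Nc2ccc(C#N)cc2)n1` gives 120000 nM
compound 2 `Cc1cc(Oc2cc(N)nc(Nc3ccc(C#N)cc3)n2)ccc1-c1ccc(C#N)cc1` gives 34300 nM
compound 3 `Cc1cc(-c2ccc(Cl)cc2)cc(C)c1Oc1cc(N)nc(Nc2ccc(C#N)cc2)n1` gives 21500 nM

Compound 3 at 21500 nM and compound 2 at 34300 nM lie within the usual scatter of each other and cannot be told apart. Compound 1 at 120000 nM stands higher than compound 3 by more than that scatter, which means that less of compound 3 is tolerated.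

Compound 4 `Cc1cc(-c2cccc(C#N)c2)cc(C)c1Oc1cc(N)nc(Nc2ccc(C#N)cc2)n1` keeps the rest of compound 3 and carries 3-cyanophenyl in place of 4-chlorophenyl on an aromatic carbon, meta to two methyl groups and para to a large group, the counted difference being 3-cyanophenyl in place of 4-chlorophenyl on an aromatic carbon and nothing else. For the measured compounds named here, no two measured compounds differ in one place only, and no measured step speaks directly to this change. Compound 1 at 120000 nM and compound 2 at 34300 nM also carry a nitrile, but they differ from compound 3 in other places too, and the hint is weak. A small rise in this assay is expected, probably not beyond the scatter, and the estimated step is a 1.4-fold higher number from compound 3 to compound 4 (0.14 log units; within the scatter) with wide uncertainty. For compound 4 the expected value is 30000 nM within an estimated range of 10000 nM to 90000 nM while the measurement is awaited.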

Compound 4, half-maximal cytotoxic concentration: 20200 nM
Beside the measured number, compound 4's estimate is 1.5-fold (0.17 log units) above it, within the range that was stated.
By their numbers in this assay, from the lowest: compounds 4, 3 and 2 (each within the scatter of the next); then compound 1.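

In this assay, for the compounds shown here, the swap gives a 1.1-fold lower number from compound 3 to compound 4 (0.03 log units; within the scatter), the only comparison here in which two compounds differ in one place. It shows that, on this aromatic carbon, meta to two methyl groups and para to a large group, 3-cyanophenyl can stand in place of 4-chlorophenyl with no readable change in tolerance, even though the chlorine leaves and a nitrile, with its hydrogen-bond acceptor, enters. No supporting measurement is available to explain this outcome.

The step changes both the substituent and where it sits on the phenyl ring, so these compounds cannot show whether either change alone would also leave the tolerance unchanged, or whether the two happen to offset each other. They also leave open whether this tolerance of the swap extends to the other compounds' cores, and whether the position would accept a very different group, such as an amine or a carboxylic acid on that phenyl ring, just as readily.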